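Swapping the Aryl Arm of a Pyridyl Ether Ligand

This account rests on a few compounds, and the source may have more. Where it says the series, first, only, none or still open, it means among the compounds named here.

Of the compounds shown here, three built on the same pyridyl ether core have been measured in an assay on membranes from brain for binding affinity to Neuronal acetylcholine receptor; alpha4/beta2 (Rattus norvegicus); a lower number here means a stronger inhibitor, a higher number a weaker inhibitor. Compound 1 `CN1CCC[C@H]1COc1cncc(-c2ccccc2C=O)c1` gives 0.56 nM, compound 2 `CN1CCC[C@H]1COc1cncc(-c2cccc([N+](=O)[O-])c2)c1` gives 0.465 nM, and compound 3 `CN1CCC[C@H]1COc1cncc(-c2cccc(N)c2)c1` gives 0.43 nM. Among the measured compounds shown here, the one single-point step among them, a 1.1-fold lower number from compound 2 to compound 3 (0.03 log units; within the scatter), leaves the number essentially unchanged. Compound 3 thus carries the lowest of the three numbers, but its separations from compound 2 and compound 1 both fall inside the scatter, so the three cannot be ranked against one another.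

Compound 4 `CN1CCC[C@H]1COc1cncc(-c2cncnc2)c1` has not been measured. It differs from compound 3 by pyrimidin-5-yl in place of 3-aminophenyl on an aromatic carbon. For the measured compounds named here, no measured step here replaces the whole aryl arm; the only available comparison, the nitro-to-amino exchange, shows that changing a group on that arm left this assay unmoved. The data therefore give no direct handle on the size of the expected step, only the observation that the arm has tolerated different substituents without large changes.

On that basis, compound 4 is expected to give 0.8 nM, with a plausible range from 0.2 nM to 3.5 nM, which corresponds to an expected step of a 1.9-fold higher number from compound 3 to compound 4 (0.27 log units; within the scatter) in this assay.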

Compound 4, inhibition constant: 0.37 nM
The estimate for compound 4 lay 2.2-fold (0.33 log units) above the measured number; low and high end bracket the measured number.
By their numbers in this assay, from the lowest: compounds 4, 3, 2 and 1 (each within the scatter of the next).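

Exchanging the whole aryl arm for pyrimidin-5-yl in this assay gives a 1.2-fold lower number from compound 3 to compound 4 (0.07 log units; within the scatter), so this position tolerates more than a change of substituent. Among the compounds shown here, the only earlier step, amino in place of nitro, kept a ring of carbon only, whereas this change replaces 3-aminophenyl with a ring holding 2 hetero atoms and removes the amino group, leaving no hydrogen-bond donors on the arm. Neither the carbon-only ring nor the hydrogen-bond donor of compound 3 is therefore needed to keep the number in this range, and the data here offer no explanation for why it holds.

On these data alone, all four compounds carry a six-membered aromatic ring at this carbon, so it remains open whether the number would hold with a saturated ring such as piperidine, a plain methyl group or a longer alkyl chain in its place. As far as these compounds go, it is also open whether a charged group such as a carboxylic acid on the arm would finally move the number in this assay beyond the scatter.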